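The source may report more compounds than this note shows. Statements on the series, on what has been measured and on what is new or still open speak of the compounds shown alone.

Compound 1 `CC(C)CCn1nc(-c2cccs2)c(O)c(C2=NS(=O)(=O)c3cc(N(C)S(C)(=O)=O)ccc3N2)c1=O`. In an ADME assay on Huh-7 cells (Homo sapiens) for cytotoxicity, with a stated time of 72 h (a higher number here means that more compound is tolerated, a lower number that less compound is tolerated), compound 1 gives > 33000 nM, which is a limit of the assay and not a number.
Compound 2 `COCN(c1ccc2c(c1)S(=O)(=O)N=C(c1c(O)c(-c3cccs3)nn(CCC(C)C)c1=O)N2)S(C)(=O)=O`. In this assay compound 2 gives > 1000 nM, again a limit of the assay.
Compound 3 `CC(C)CCn1nc(C2CCCC2)c(O)c(C2=NS(=O)(=O)c3cc(NS(C)(=O)=O)ccc3N2)c1=O`. In this assay compound 3 gives > 1000 nM, also a limit of the assay.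

Compound 3 therefore stands at the limit of > 1000 nM in this assay, at which 2 of the 3 values shown sit; compound 1 stands at the limit of > 33000 nM in this assay, at which 1 of the 3 values shown sits. Within the data shown here, the only measured pair that differs in one place is compound 1 and compound 2, and there the step that the two limits leave unreadable from compound 1 to compound 2 cannot be read, since both ends are limits. That change sits at a sulfonamide nitrogen and not at the aromatic carbon concerned here.

Compound 4 `CC(C)CCn1nc(CCC(F)(F)F)c(O)c(C2=NS(=O)(=O)c3cc(NS(C)(=O)=O)ccc3N2)c1=O` differs from compound 3 by 3,3,3-trifluoropropyl in place of cyclopentyl on an aromatic carbon. Among the measured compounds shown here, no measured step bears on this change, so there is no basis to expect a step beyond the scatter in either direction in this assay; the expectation is simply that compound 4 stays near the limit where compound 3 sits, with the estimated step that the limit leaves unreadable from compound 3 to compound 4 meaning no real movement. Compound 4 is expected to give about 20000 nM, within a range from 3000 nM to 60000 nM, most likely reported again only as a limit.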

Compound 4, half-maximal cytotoxic concentration: > 33000 nM
Compound 4 gave a limit, no number; the forecaster's own chance of this, stated with the estimate: 75%; at least 1.6-fold (0.21 log units) between middle value and limit.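

Compound 3 and compound 4 are both reported only as limits of the assay and not as numbers, and the step between them cannot be read. On these data alone, it remains open whether 3,3,3-trifluoropropyl in place of cyclopentyl on an aromatic carbon moves the half-maximal cytotoxic concentration at all in this assay, and in which direction.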